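A Thiophene Replaces Naphthalene on a Shared Core

The source may report more compounds than this note shows. Statements on the series, on what has been measured and on what is new or still open speak of the compounds shown alone.

Of the compounds shown here, two built on a shared core have so far been measured in a functional assay on NCI-H23 cells (Homo sapiens) for inhibition, read by sulforhodamine B assay, with a stated time of 48 h, tested at 10 uM; on this read-out higher numbers stand for more inhibition at the one concentration tested (going by the name of the read-out) and lower numbers for less inhibition. Compound 1 `c1ccc2c(-c3cn4ccnc4c(-c4ccc5ncn(C6CCCCC6)c5c4)n3)cccc2c1` gives 4.32% in this assay, and compound 2 `Fc1ccc(-c2cn3ccnc3c(-c3ccc4ncn(C5CCCCC5)c4c3)n2)cc1` gives 2.36%. Of the two numbers compound 1 holds the highest, yet its nearest neighbour, compound 2, sits within the scatter of it, so the two cannot be told apart. Going by the values given here, the single measured step, a number 2 percentage points lower from compound 1 to compound 2 (within the scatter), exchanges the group at the very position at issue here.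

Compound 3 `c1csc(-c2cn3ccnc3c(-c3ccc4ncn(C5CCCCC5)c4c3)n2)c1` has not yet been measured. It differs from compound 1 as follows: thiophen-2-yl in place of naphthalen-1-yl on an aromatic carbon. Among the compounds with values here, the only step that bears on this change is the one just named, and it was small, a number 2 percentage points lower from compound 1 to compound 2 (within the scatter). Both measured numbers are low at the tested concentration. On that basis compound 3 is expected to show a step of a number 1.3 percentage points lower from compound 1 to compound 3 (within the scatter), that is, nothing beyond the scatter. Compound 3 is therefore estimated at 3%, with an expected range from -5% to 12%.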

Compound 3, a percentage reported as inhibition, at one concentration (the size of the read-out at that concentration, not a potency): 5.95%
Compound 3: middle estimate off by 3 percentage points, on the low side; the range from low to high includes it.
By their numbers in this assay, from the lowest: compounds 2, 1 and 3 (each within the scatter of the next).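

In this assay, this position, on an aromatic carbon next to the ring nitrogen, now carries thiophen-2-yl, a single five-membered aromatic ring with 1 hetero atom, and exchanging naphthalen-1-yl, with its 2 six-membered aromatic rings of carbon only, for this group gives a number 1.6 percentage points higher from compound 1 to compound 3 (within the scatter). Exchanging 4-fluorophenyl for thiophen-2-yl gives a number 3.6 percentage points higher from compound 2 to compound 3 (within the scatter), so neither new step separates compound 3 from the earlier compounds, and the three aromatic groups shown, which include one of 10 heavy atoms and one of 5, cannot be told apart here. No independent measurement is available to say what lies behind these closely matched numbers.

Going by these compounds, it remains open whether a non-aromatic group at this position, such as a primary amine, a carboxylic acid or a longer alkyl chain, would produce a step beyond the scatter. Since each compound is read at only one concentration, the numbers also leave open how any of the three would behave at higher concentrations and what its potency would be.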